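Swapping the Carboxy Group for a Tetrazole Ring

The compounds below may be only part of what the source reports. "The series", "measured", "known", "first", "only" and "open" are said of these compounds alone.

In a functional assay for inhibition, with Homo sapiens as the target (a lower number here means a stronger inhibitor, a higher number a weaker inhibitor), compound 1 `COCc1cc(-c2ccccc2)c2ccc(OCc3cccc(C4(O)CCOCC4)c3)cc2c1` gives 4 nM, while compound 2 `O=C(O)c1cc(-c2ccccc2)c2ccc(OCc3cccc(C4(O)CCOCC4)c3)cc2c1` gives 190 nM. Compound 2 therefore holds the higher of the two numbers and is the weaker inhibitor of the pair.

Compound 3 `OC1(c2cccc(COc3ccc4c(-c5ccccc5)cc(-c5nn[nH]n5)cc4c3)c2)CCOCC1` keeps the core of compound 2 and changes one group, with 2H-tetrazol-5-yl in place of carboxy on an aromatic carbon.

Among the measured compounds shown here, only one measured step bears on this change. Carboxy in place of methoxymethyl gave a large step, a 48-fold higher number from compound 1 to compound 2 (1.68 log units; beyond the scatter). It shows that a change at this place can move the number a long way, but it does not test a replacement of the carboxy group itself. For the measured compounds named here, with no such step measured, the starting point for the forecast is compound 2 at 190 nM, and the range must stay wide.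

In this assay, the expected change is a 1.3-fold lower number from compound 2 to compound 3 (0.10 log units; within the scatter), which means no clear step beyond the scatter and no firm direction. For compound 3, the estimated value is 150 nM, within an expected range of 40 nM to 600 nM.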

Compound 3, half-maximal inhibitory concentration: > 700 nM
Compound 3: a limit, no number (the forecaster's own chance of this, stated with the estimate: 3%); middle value at least 4.6-fold (0.66 log units) from the limit.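

In this assay compound 3 gives > 700 nM, which is a limit of the assay and not an exact number: the limit of > 700 nM in this assay, at which 1 of the 3 values shown sits.

Even so, the limit is enough to read a direction, because replacing carboxy with 2H-tetrazol-5-yl gives an at least 3.6-fold higher number from compound 2 to compound 3 (0.56 log units; beyond the scatter), so this position does not treat the two groups as interchangeable, something the earlier pair could not show. Set against the methoxymethyl group, the same ring gives an at least 170-fold higher number from compound 1 to compound 3 (2.24 log units; beyond the scatter), so both replacements of methoxymethyl shown here raise the number, and the ring raises it further than carboxy does.

Going by these compounds, the true value of compound 3 remains open, and with it the full size of both steps. Three groups at one position also cannot show which feature of methoxymethyl goes with the low number, and a hydroxymethyl group, a plain methyl group or a primary amide at the same place would help to separate what matters there.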